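A few compounds are considered here, and "the series" means these few. Any claim that something is new, unique, unknown or untested is made for them only; others in the source may bear on it.

The measured compounds are compound 1 `COc1ccccc1N1CCN(C(=S)SCC(O)Cn2c([N+](=O)[O-])cnc2C)CC1`, compound 2 `Cc1ncc([N+](=O)[O-])n1CC(O)CSC(=S)N1CCN(c2ccccn2)CC1` and compound 3 `COc1ccccc1N1CCN(CC(O)Cn2c([N+](=O)[O-])cnc2C)CC1`. In a toxicity assay on HeLa cells (Homo sapiens) for cytotoxicity, read by MTT assay, with a stated time of 24 h (on this read-out higher numbers stand for weaker inhibition and lower numbers for stronger inhibition), compound 1 gives only a limit of the assay, > 5000000 nM. In this assay compound 2 gives 2970000 nM. In this assay compound 3 gives 4390000 nM, and compound 3 and compound 2 sit within the scatter of each other. Compound 4 `Cc1ncc([N+](=O)[O-])n1CC(O)CN1CCN(c2ccccn2)CC1` has not yet been measured.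

The change made from compound 1 to compound 2 is pyridin-2-yl in place of 2-methoxyphenyl on an amine nitrogen in a ring, and it gave an at least 1.6-fold lower number from compound 1 to compound 2 (0.22 log units; that floor lies within the scatter). The change made from compound 3 to compound 4 is pyridin-2-yl in place of 2-methoxyphenyl on an amine nitrogen in a ring, the same change at the same place. How the core of compound 1 differs from the core of compound 3 is not broken down here.

Resting on an at least 1.6-fold lower number from compound 1 to compound 2 (0.22 log units; that floor lies within the scatter), a step of similar small size, within the scatter, is expected: a 1.5-fold lower number from compound 3 to compound 4 (0.17 log units; within the scatter). Compound 4 is therefore estimated at 3000000 nM, with a likely range from 1500000 nM to 6000000 nM.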

Compound 4, half-maximal inhibitory concentration: 1830000 nM
The estimate for compound 4 lay 1.6-fold (0.21 log units) above the measured number; the range from low to high includes it.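

In this assay, putting pyridin-2-yl in place of 2-methoxyphenyl gives a 2.4-fold lower number from compound 3 to compound 4 (0.38 log units; beyond the scatter), so on this core the change lowers the number by a modest but readable amount. The same change on the core of compound 1 points the same way, but two cores are too few to show a general rule, and the size of the earlier step stays unsettled: the same change on two cores in this assay, an at least 1.6-fold lower number (0.22 log units; that floor lies within the scatter) from compound 1 to compound 2 and a 2.4-fold lower number (0.38 log units; beyond the scatter) from compound 3 to compound 4; the limit leaves it open whether they differ Compound 1 is recorded only as a limit of the assay, not as a number: the limit of > 5000000 nM in this assay, at which 1 of the 4 values shown sits.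

The compounds shown leave open how a plain phenyl or a pyrimidinyl group on the same amine nitrogen would compare. They also leave open whether the step would hold on a core with a longer chain.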